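Ring-closing the amine on the pyridine core of compound 3

The source may report more compounds than this note shows. Statements on the series, on what has been measured and on what is new or still open speak of the compounds shown alone.

Compound 1 `CCCCNc1nc(C(F)(F)F)ccc1CNC(=O)C(C)c1ccc(NS(C)(=O)=O)c(F)c1` gives 293 nM in a functional assay on CHO-K1 cells for antagonist activity at transient receptor potential cation channel subfamily V member 1 (Homo sapiens), read by FLIPR; a lower number here means a stronger inhibitor, a higher number a weaker inhibitor.
Compound 2 `CC(C(=O)NCc1ccc(C(F)(F)F)nc1N(C)C)c1ccc(NS(C)(=O)=O)c(F)c1` gives 2390 nM in this assay.
Compound 3 `CCCN(CCC)c1nc(C(F)(F)F)ccc1CNC(=O)C(C)c1ccc(NS(C)(=O)=O)c(F)c1` gives 14.7 nM in this assay.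

Among the three measured compounds, compound 3 has the lowest number: the step from compound 1 is a 20-fold lower number from compound 1 to compound 3 (1.30 log units; beyond the scatter), and that from compound 2 is a 160-fold lower number from compound 2 to compound 3 (2.21 log units; beyond the scatter). Compound 4 `CC(C(=O)NCc1ccc(C(F)(F)F)nc1N1CCC(C)(C)CC1)c1ccc(NS(C)(=O)=O)c(F)c1` has not yet been measured. It differs from compound 3 in one place: 4,4-dimethylpiperidin-1-yl in place of dipropylamino on an aromatic carbon, on an aromatic carbon of a six-membered aromatic ring with one nitrogen, next to the ring nitrogen, ortho to a large group and meta to a trifluoromethyl group. Going by the values given here, the steps that bear on this change are a 20-fold lower number from compound 1 to compound 3 (1.30 log units; beyond the scatter) and a 160-fold lower number from compound 2 to compound 3 (2.21 log units; beyond the scatter), both large and both going toward a lower number as the amino group on this carbon grows from dimethylamino through butylamino to dipropylamino. Compound 4 keeps an amino group of comparable size, now closed into a ring, so the expectation is a number close to that of compound 3, with an expected step of a 1.5-fold higher number from compound 3 to compound 4 (0.18 log units; within the scatter). Compound 4 is therefore estimated at 22 nM, within a range of 6 nM to 90 nM.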

Compound 4, half-maximal inhibitory concentration: 8 nM
Beside the measured number, compound 4's estimate is 2.8-fold (0.44 log units) above it, and the stated range covers the measured number.
By their numbers in this assay, from the lowest: compounds 4 and 3 (each within the scatter of the next); then compound 1; then compound 2.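

Closing the two propyl chains of dipropylamino into the ring of 4,4-dimethylpiperidin-1-yl leaves the reading in this assay within the scatter (a 1.8-fold lower number from compound 3 to compound 4 (0.26 log units; within the scatter)), so on this aromatic carbon a low number does not depend on open chains. The ring also holds the large distance from the other two amino groups, seen with dimethylamino (a 300-fold lower number from compound 2 to compound 4 (2.48 log units; beyond the scatter)) and with butylamino (a 37-fold lower number from compound 1 to compound 4 (1.56 log units; beyond the scatter)). Nothing measured here accounts for these differences.

The compounds shown leave open how much the two methyl groups on the ring contribute, which plain piperidin-1-yl would test, and whether a ring oxygen, as in morpholin-4-yl, would be accepted on this carbon. They also leave open whether a larger ring, such as azepan-1-yl, would keep the number this low.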